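A few compounds are considered here, and "the series" means these few. Any claim that something is new, unique, unknown or untested is made for them only; others in the source may bear on it.

Measured compounds:
compound 1, `Oc1ccc2c(c1)CCc1ccc(O)c(c1)Oc1ccc(cc1)CCc1cccc(O)c1O2` — in a functional assay on HeLa cells (Homo sapiens) for antiproliferative activity, read by MTT assay, with a stated time of 48 h (a lower number here means a stronger inhibitor, a higher number a weaker inhibitor), compound 1 gives 15900 nM.
compound 2, `Oc1cc2c(cc1O)Oc1c(O)cccc1CCc1ccc(cc1)Oc1cc(ccc1O)CC2` — in this assay compound 2 gives 10400 nM.
compound 3, `Oc1ccc2cc1Oc1ccc(cc1)CCc1cccc(O)c1Oc1ccc(cc1)CC2` — in this assay compound 3 gives 10500 nM.

Compound 3 stands close to compound 2 and to compound 1, all three values lying within the usual scatter of one another. Compound 4, `Oc1ccc2cc1Oc1ccc(cc1)CCc1cccc(O)c1Oc1ccc(cc1O)CC2`, is not yet measured.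

The only single step shown among the measured compounds runs from compound 1 to compound 2: hydroxy in place of hydrogen on an aromatic carbon. Its size in this assay is a 1.5-fold lower number from compound 1 to compound 2 (0.18 log units; within the scatter).

Compound 4 differs from compound 3 by the same kind of change: hydroxy in place of hydrogen on an aromatic carbon. The surroundings of the place are not identical: in the earlier step the entering hydroxy sits ortho to a hydroxy group, meta to a fused ring and para to a fused ring, whereas here it sits ortho to a fused ring and meta to a fused ring. How the core of compound 1 differs from the core of compound 3 is not broken down here.

Resting on a 1.5-fold lower number from compound 1 to compound 2 (0.18 log units; within the scatter), the step from compound 3 to compound 4 in this assay is expected to be a 1.2-fold lower number from compound 3 to compound 4 (0.09 log units; within the scatter), small and within the scatter. Compound 4 is therefore estimated at 8500 nM, with a range from 4000 nM to 18000 nM.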

Compound 4, half-maximal inhibitory concentration: 27400 nM
Beside the measured number, compound 4's estimate is 3.2-fold (0.51 log units) below it; measured number above the stated range.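

In this assay, hydroxy in place of hydrogen on an aromatic carbon gives a 2.6-fold higher number from compound 3 to compound 4 (0.42 log units; beyond the scatter) and so does not carry over unchanged to this core. Set beside the earlier step, the two readings disagree: the same change on two cores in this assay, a 1.5-fold lower number (0.18 log units; within the scatter) from compound 1 to compound 2 and a 2.6-fold higher number (0.42 log units; beyond the scatter) from compound 3 to compound 4, 4.0-fold (0.60 log units) apart, beyond the scatter of two such steps. Among these compounds, this rests on only two pairs, and the hydroxy entering compound 4 sits ortho to a fused ring and meta to a fused ring, a different place from the earlier step, so the data neither separate an effect of the core from one of the place nor show a general rule for the series.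

The compounds shown leave open whether the same change at other places on the core of compound 3 would also give a higher number, or whether the result is tied to this one place. Also open, going by these compounds, is how a methoxy group or an amine at this same place would compare with the hydroxy of compound 4.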